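Replacing 4-(dimethylamino)phenyl with pyridin-2-yl on a shared core

This account rests on a few compounds, and the source may have more. Where it says the series, first, only, none or still open, it means among the compounds named here.

Compound 1 `O=C(c1ccccc1)N1CCC(NS(=O)(=O)c2cc(S(=O)(=O)c3ccccc3)ccc2C(F)(F)F)CC1` gives 12500 nM
Compound 2 `O=C(c1cccc(Cl)c1)N1CCC(NS(=O)(=O)c2cc(S(=O)(=O)c3ccccc3)ccc2C(F)(F)F)CC1` gives 6300 nM
Compound 3 `CN(C)c1ccc(C(=O)N2CCC(NS(=O)(=O)c3cc(S(=O)(=O)c4ccccc4)ccc3C(F)(F)F)CC2)cc1` gives 50000 nM

In a physicochemical assay for solubility (on this read-out lower numbers stand for lower solubility and higher numbers for higher solubility), compound 3 stands highest of the three, with its reading of 50000 nM beyond the scatter of both others. The next molecule is compound 4 `O=C(c1ccccn1)N1CCC(NS(=O)(=O)c2cc(S(=O)(=O)c3ccccc3)ccc2C(F)(F)F)CC1`, and its difference from compound 3 is this: pyridin-2-yl in place of 4-(dimethylamino)phenyl on a carbonyl carbon. The swap takes place on a carbonyl carbon. Within the data shown here, no measured step introduces pyridin-2-yl, so the evidence is indirect. Compound 4 lacks the dimethylamino group, as compound 1 does, and the closest guide is a 4.0-fold higher number from compound 1 to compound 3 (0.60 log units; beyond the scatter) for dimethylamino in place of hydrogen. The step of a 2.0-fold lower number from compound 1 to compound 2 (0.30 log units; within the scatter) shows a chloro change that stays within the scatter. Nothing measured here shows what the ring nitrogen of pyridin-2-yl does. A modest fall is therefore expected, and the estimate is a 2.5-fold lower number from compound 3 to compound 4 (0.40 log units; beyond the scatter) in this read-out. For compound 4 the expected value is 20000 nM, with an estimated range from 8000 nM to 50000 nM as the likely span.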

Compound 4, solubility: 100000 nM
The estimate for compound 4 lay 5.0-fold (0.70 log units) below the measured number; measured number above the stated range.
By their numbers in this assay, from the lowest: compounds 2 and 1 (each within the scatter of the next); then compounds 3 and 4 (each within the scatter of the next).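

In this assay, pyridin-2-yl in place of phenyl on the carbonyl carbon gives an 8.0-fold higher number from compound 1 to compound 4 (0.90 log units; beyond the scatter), and pyridin-2-yl in place of 3-chlorophenyl gives a 16-fold higher number from compound 2 to compound 4 (1.20 log units; beyond the scatter), showing that changing the ring itself, with no substituent added, can shift the reading beyond the scatter. The remaining step, a 2.0-fold higher number from compound 3 to compound 4 (0.30 log units; within the scatter), leaves pyridin-2-yl and 4-(dimethylamino)phenyl indistinguishable here, so two quite different groups on this carbonyl carbon give readings that cannot be separated. No measurement available here explains why these readings come out as they do.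

The compounds shown leave open whether the effect depends on where the ring nitrogen sits, as pyridin-3-yl would test. They also leave open how a non-aromatic group on this carbonyl carbon, such as an aliphatic amine or a carboxylic acid, would read.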